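The source may report more compounds than this note shows. Statements on the series, on what has been measured and on what is new or still open speak of the compounds shown alone.

Three closely related amides have been measured so far. In a functional assay on OVCAR-5 cells (Homo sapiens) for inhibition, read by CCK-8 assay, with a stated time of 72 h, tested at 10 uM (on this read-out lower numbers stand for less inhibition of growth and higher numbers for more inhibition of growth at the one concentration tested), compound 1 (`CN(C)C(=O)c1cc2cnc(Nc3ccc(NC(=O)C4(C(=O)Nc5ccc(F)cc5)CC4)cc3)nc2n1C1CCCC1`) gives 79.7%, compound 2 (`CN(C)C(=O)c1cc2cnc(Nc3ccc(NC(=O)C4(C(=O)Nc5cccc(F)c5)CC4)cc3)nc2n1C1CCCC1`) gives 85.6%, and compound 3 (`CN(C)C(=O)c1cc2cnc(Nc3ccc(NC(=O)C4(C(=O)Nc5ccc(Br)cc5)CC4)cc3)nc2n1C1CCCC1`) gives 87.8%. Compound 1 therefore stands within the scatter of both neighbours, and the three values cannot be ranked.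

The unmeasured compound 4 (`CN(C)C(=O)c1cc2cnc(Nc3ccc(NC(=O)C4(C(=O)Nc5ccc(Cl)c(C(F)(F)F)c5)CC4)cc3)nc2n1C1CCCC1`) keeps the core of compound 1 and changes only the aryl group: 4-chloro-3-(trifluoromethyl)phenyl in place of 4-fluorophenyl on an amide-type nitrogen. This means 4-chloro-3-(trifluoromethyl)phenyl in place of 4-fluorophenyl on an amide-type nitrogen.

Among the measured compounds shown here, two measured steps bear most directly on this change, as both alter the same aryl group of compound 1. The first is a number 5.9 percentage points higher from compound 1 to compound 2 (within the scatter), for 3-fluorophenyl in place of 4-fluorophenyl. The second is a number 8.1 percentage points higher from compound 1 to compound 3 (within the scatter), for bromo in place of fluoro. The remaining step, a number 2.2 percentage points higher from compound 2 to compound 3 (within the scatter), is also small. For the measured compounds named here, no measured compound carries chloro or trifluoromethyl, so the new group itself remains untested, and the evidence is only indirect.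

With all three steps inside the scatter, no change beyond the scatter is expected in this assay, although both steps from compound 1 point slightly upward. The estimated step is a number 6.3 percentage points higher from compound 1 to compound 4 (within the scatter). For compound 4, the expected value is 86%, with an estimated range from 76% to 95%.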

Compound 4, percent growth inhibition at one concentration: 48%
Beside the measured number, compound 4's estimate is 38 percentage points above it, outside the stated range (below it).
By their numbers in this assay, from the lowest: compound 4; then compounds 1, 2 and 3 (each within the scatter of the next).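

In this assay, among the compounds shown here, the aryl group on the amide-type nitrogen turns out not to be indifferent to change: 4-chloro-3-(trifluoromethyl)phenyl in place of 4-fluorophenyl gives a number 31.7 percentage points lower from compound 1 to compound 4 (beyond the scatter) and so moves the read-out beyond the scatter, which no earlier step at this place did. The picture is the same against the other two aryl groups, with a number 37.6 percentage points lower from compound 2 to compound 4 (beyond the scatter) for the replacement of 3-fluorophenyl and a number 39.8 percentage points lower from compound 3 to compound 4 (beyond the scatter) for the replacement of 4-bromophenyl, so the fall does not depend on which of the three measured groups serves as the reference. The room for change seen among compounds 1, 2 and 3, each with a single halogen on the phenyl ring, therefore does not extend to this group, which enters with 11 heavy atoms where 4-fluorophenyl has 7.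

On these data alone, compound 4 brings in chloro and trifluoromethyl together, so it remains open whether either alone would lower the number, and how a phenyl group carrying only chloro, only trifluoromethyl, or instead a methoxy group or an amine would behave at this place. Nothing among the data shown explains the fall in growth inhibition.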